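The source may hold more compounds than are shown below. What is called first, only, known or untested is meant among the compounds shown, and "the series" means these compounds.

Of the compounds shown here, three have numbers so far in a functional assay on Ehrlich cells (Mus musculus) for cytotoxicity, read by LDH release, with a stated time of 48 h; on this read-out lower numbers stand for stronger inhibition and higher numbers for weaker inhibition. Compound 1 (`Cc1ccc(C(=O)c2ccc(OCC(=O)Nc3nc(-c4ccccc4)cs3)c(C)c2)cc1`) gives 30500 nM, compound 2 (`COc1ccc(-c2csc(NC(=O)COc3ccc(C(=O)c4ccc(C)cc4)cc3C)n2)cc1`) gives 20900 nM and compound 3 (`Cc1cc(C(=O)c2ccccc2)cc(C)c1OCC(=O)Nc1nc(-c2ccccc2)cs1`) gives 23400 nM. Compound 2 therefore lies within the scatter of both compound 1 and compound 3, and no clear separation appears among the values around it.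

The next compound is compound 4 (`COc1ccc(-c2csc(NC(=O)COc3ccc(C(=O)c4ccc(F)cc4)cc3C)n2)cc1`). The change is fluoro in place of methyl on an aromatic carbon, which is fluoro in place of methyl on an aromatic carbon, para to a large group, so 4-methylphenyl becomes 4-fluorophenyl.

Among the compounds with values here, only one single-place step has been measured, a 1.5-fold lower number from compound 1 to compound 2 (0.16 log units; within the scatter). It concerns methoxy in place of hydrogen, a different change, and it stays within the scatter. Within the data shown here, no measured step replaces this methyl, so the evidence is indirect, and no step beyond the scatter is expected in this assay. The estimated step is a 1.0-fold lower number from compound 2 to compound 4 (0.02 log units; within the scatter). For compound 4 the expected value is 20000 nM, with an estimated range of 9000 nM to 42000 nM.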

Compound 4, half-maximal inhibitory concentration: 5800 nM
Compound 4: the middle estimate sits 3.4-fold (0.54 log units) above what was measured, and the stated range ends above it.
By their numbers in this assay, from the lowest: compound 4; then compounds 2, 3 and 1 (each within the scatter of the next).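

In this assay, within the data shown here, the change from 4-methylphenyl to 4-fluorophenyl gives a 3.6-fold lower number from compound 2 to compound 4 (0.56 log units; beyond the scatter) and is the only single-place step here beyond the scatter, whereas a 1.5-fold lower number from compound 1 to compound 2 (0.16 log units; within the scatter) stays within it. The aromatic carbon para to a large group is therefore a place where exchanging one heavy atom, with no change in ring, hydrogen-bond donors, hydrogen-bond acceptors or net charge, separates two compounds in this series. No measured property of methyl or fluoro is available to bear on this step.

The compounds shown compare only methyl and fluoro at this place, so how hydrogen, chloro, an amine or a carboxylic acid there would read remains open. Also open, from the compounds shown here alone, is whether fluoro in place of methyl gives a step of similar size on the core of compound 1, which carries no methoxy.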